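Arylamide replacement of the ethyl amide on the core

The source may hold more compounds than are shown below. What is called first, only, known or untested is meant among the compounds shown, and "the series" means these compounds.

Compound 1 `CCNC(=O)CCc1cccc2c1B(O)OC2` carries an ethyl group on the amide nitrogen of the shared core. In a functional assay on HCT-116 cells (Homo sapiens) for antiproliferative activity, read by MTT assay, with a stated time of 72 h (on this read-out lower numbers stand for stronger inhibition and higher numbers for weaker inhibition), compound 1 gives only a limit, > 100000 nM. Compound 2 `O=C(CCc1cccc2c1B(O)OC2)NC1CCCCC1` also gives only a limit in this assay, > 100000 nM. Because both sit at the limit of > 100000 nM in this assay, at which 2 of the 3 values shown sit, the step that the two limits leave unreadable from compound 1 to compound 2 cannot be read. Among the compounds with values here, compound 3 `C#Cc1ccc(NC(=O)CCc2cccc3c2B(O)OC3)cc1`, an aryl amide, gives 45000 nM in this assay, the single numerical value in the set.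

Compound 4 `O=C(CCc1cccc2c1B(O)OC2)Nc1cccc(Br)c1` differs from compound 1 by 3-bromophenyl in place of ethyl on an amide-type nitrogen. Within the data shown here, no measured step reads directly on this change, the only measured step being unreadable. The closest guide is compound 3, which shows that an aryl amide on this core can reach a measurable number, 45000 nM. Compound 4 is therefore expected to land near that value rather than at the limit, though a limit remains possible. In this assay compound 4 is estimated at 50000 nM, in the range 15000 nM to 150000 nM. The step of an at least 2.0-fold lower number from compound 1 to compound 4 (0.30 log units; that floor lies within the scatter) is the expected consequence, read loosely since it starts from a limit.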

Compound 4, half-maximal inhibitory concentration: 1400 nM
Compound 4: the middle estimate sits 36-fold (1.55 log units) above what was measured; the whole stated range lies above it.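

On the amide-type nitrogen, 3-bromophenyl in place of ethyl brings an at least 71-fold lower number from compound 1 to compound 4 (1.85 log units; beyond the scatter), and 3-bromophenyl in place of cyclohexyl brings an at least 71-fold lower number from compound 2 to compound 4 (1.85 log units; beyond the scatter). Both sizes are floors, since each step starts from a limit: the limit of > 100000 nM in this assay, at which 2 of the 4 values shown sit.

The group on this nitrogen can thus carry the shared core well into the measurable range of this assay, and an aryl amide alone does not fix the number: compound 3 gives 45000 nM and compound 4 gives 1400 nM.

Open, as far as these compounds go, is how much of this belongs to the bromine and how much to the aromatic ring, a question that an unsubstituted phenyl on the same nitrogen would address. Also open, from the compounds shown here alone, is whether a benzyl group on that nitrogen, or a longer chain between the shared core and the carbonyl, would keep the number of compound 4.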